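The source may hold more compounds than are shown below. What is called first, only, known or untested is meant among the compounds shown, and "the series" means these compounds.

Measured so far in a functional assay on SMMC-7721 cells (Homo sapiens) for antiproliferative activity, read by MTT assay, with a stated time of 72 h; on this read-out lower numbers stand for stronger inhibition and higher numbers for weaker inhibition:
- compound 1 `CN(C(=O)c1ccc(F)cc1)c1ccc2[nH]c(-c3n[nH]c4ccccc34)cc2n1`: compound 1 gives 9150 nM
- compound 2 `CN(C(=O)c1ccccc1)c1ccc2[nH]c(-c3n[nH]c4cc(Cl)ccc34)cc2n1`: compound 2 gives 11300 nM

Compound 1 stands at the lower of the two numbers in this assay, but its gap to compound 2 is within the scatter, so the two values show no difference that can be read as an order. For the measured compounds named here, no single-point step between measured compounds is available, so nothing measured tells how a change at the nitrogen on the aromatic ring moves the read-out.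

Compound 3 `CN(c1ccc2[nH]c(-c3n[nH]c4ccccc34)cc2n1)S(=O)(=O)c1ccccc1` is the next candidate. Relative to compound 1 it carries phenylsulfonyl in place of (4-fluorophenyl)carbonyl on a nitrogen on an aromatic ring. Going by the values given here, with no comparable step measured, the expectation for this assay is a change no larger than the scatter, in no fixed direction. Compound 3 is therefore expected at 10000 nM, within 3000 nM to 35000 nM, which amounts to an expected step of a 1.1-fold higher number from compound 1 to compound 3 (0.04 log units; within the scatter).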

Compound 3, half-maximal inhibitory concentration: 12000 nM
Estimate against measurement, compound 3: 1.2-fold (0.08 log units) below, within the range that was stated.
By their numbers in this assay, from the lowest: compounds 1, 2 and 3 (each within the scatter of the next).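

For the compounds shown here, this is the first single-place step: in this assay, phenylsulfonyl in place of (4-fluorophenyl)carbonyl on a nitrogen on an aromatic ring gives a 1.3-fold higher number from compound 1 to compound 3 (0.12 log units; within the scatter). At this position, the two groups therefore show no difference that can be read, although the exchange replaces the carbonyl with a sulfonyl and removes the fluorine in a single step. Nothing available here bears on why the read-out holds across this exchange.

With both features changing together, the separate contribution of the sulfonyl and of the fluorine stays unresolved. As far as these compounds go, it also stays open whether a different kind of group on this nitrogen, such as a longer alkyl chain, or a carboxylic acid or an amine on the phenyl ring, would move the read-out beyond the scatter.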